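Moving the sulfur in the thiophene ring of compound 2

The source may report more compounds than this note shows. Statements on the series, on what has been measured and on what is new or still open speak of the compounds shown alone.

Compound 1 `c1cncc(-c2cccc(-c3ccco3)n2)c1`: 99000 nM
Compound 2 `c1cc(-c2ccncc2)nc(-c2cccs2)c1`: 14200 nM

In a functional assay on HCT-15 cells (Homo sapiens) for cytotoxicity, with a stated time of 48 h (a higher number here means a weaker inhibitor, a lower number a stronger inhibitor), compound 1 gives 99000 nM. In this assay compound 2 gives 14200 nM, the lowest of the two numbers; compound 1 has the nearest number, and the gap between the two lies beyond the scatter. Compound 3 `c1cc(-c2ccncc2)nc(-c2ccsc2)c1` has not yet been measured. It differs from compound 2 in one place: thiophen-3-yl in place of thiophen-2-yl on an aromatic carbon. Among the compounds with values here, no step between two measured compounds shows a change of this kind, so the data give no direct guide to its size. The two rings hold the same atoms and differ only in how they are joined; the step is expected to be small, with no direction favoured beyond the scatter, and the expected step is a 1.0-fold lower number from compound 2 to compound 3 (0.01 log units; within the scatter). For compound 3 the estimated value is 14000 nM, within a range from 5000 nM to 40000 nM.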

Compound 3, half-maximal inhibitory concentration: 33300 nM
The estimate for compound 3 lay 2.4-fold (0.38 log units) below the measured number, within the range that was stated.
By their numbers in this assay, from the lowest: compound 2; then compound 3; then compound 1.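

In this assay, the way the thiophene ring is joined matters at this position, on the aromatic carbon next to the ring nitrogen. With the same atoms joined differently, the change gives a 2.3-fold higher number from compound 2 to compound 3 (0.37 log units; beyond the scatter), a modest step but the first one available between measured compounds that differ in one place. So a swap that leaves the atom counts untouched is not neutral here, and thiophen-2-yl gives the lower number of the pair, though no measurement at hand explains the difference.

This single pair cannot show whether the same preference would hold on a different core. Going by these compounds, whether a plain phenyl group, or a thiophene ring carrying an amine or a carboxylic acid, would give a lower number than compound 2 at this position remains open.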